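Methyl in Place of Chloro on a Shared Core

This account rests on a few compounds, and the source may have more. Where it says the series, first, only, none or still open, it means among the compounds named here.

Measured in an assay on HEK293 cells for inhibition of acid ceramidase (Homo sapiens), with a stated time of 10 min; a higher number here means a weaker inhibitor, a lower number a stronger inhibitor:
Compound 1 `O=C(NCCCCc1ccccc1)n1c(=O)oc2ccccc21` gives 64 nM.
Compound 2 `COc1ccc(-c2ccc3c(c2)oc(=O)n3C(=O)NCCCCc2ccccc2)cc1` gives 67 nM.
Compound 3 `O=C(NCCCCc1ccccc1)n1c(=O)oc2cc(Cl)ccc21` gives 33 nM.

Compound 3 carries the lowest of the three numbers, reached by a 1.9-fold lower number from compound 1 to compound 3 (0.29 log units; within the scatter) and by a 2.0-fold lower number from compound 2 to compound 3 (0.31 log units; beyond the scatter). Compound 4 `Cc1ccc2c(c1)oc(=O)n2C(=O)NCCCCc1ccccc1` differs from compound 3 by methyl in place of chloro on an aromatic carbon. Among the measured compounds shown here, no measured step swaps chloro for methyl; the closest guides are the two steps that brought chloro in, a 1.9-fold lower number from compound 1 to compound 3 (0.29 log units; within the scatter) and a 2.0-fold lower number from compound 2 to compound 3 (0.31 log units; beyond the scatter), both modest. As the departing and the entering group each count one heavy atom at the same place, the step expected from compound 3 to compound 4 is a 1.4-fold higher number from compound 3 to compound 4 (0.13 log units; within the scatter), not beyond the scatter. Compound 4 is therefore estimated at 45 nM in this assay, with a likely range from 22 nM to 90 nM.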

Compound 4, half-maximal inhibitory concentration: 66 nM
Compound 4: the middle estimate sits 1.5-fold (0.17 log units) below what was measured; the measured number falls inside the stated range.
By their numbers in this assay, from the lowest: compounds 3, 1, 4 and 2 (each within the scatter of the next, the first and the last beyond it).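

Methyl gives a number matching that of hydrogen at this position on the shared core (a 1.0-fold higher number from compound 1 to compound 4 (0.01 log units; within the scatter)) and matching that of the much larger 4-methoxyphenyl (a 1.0-fold lower number from compound 2 to compound 4 (0.01 log units; within the scatter)). It also stays within the scatter of chloro (a 2.0-fold higher number from compound 3 to compound 4 (0.30 log units; within the scatter)), so swapping one single-heavy-atom group for the other has no readable effect here. Among compounds 1, 2 and 4 the group at this position makes no readable difference, and compound 3 alone stands apart, beyond the scatter from compound 2 only.

Going by these compounds, whether an amine or a carboxylic acid at this position would keep the number in the same range stays open. Nothing available explains why these groups give such similar numbers.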